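The source may hold more compounds than are shown below. What is called first, only, known or untested is meant among the compounds shown, and "the series" means these compounds.

Working notes on the series. Of the compounds shown here, three have numbers so far in a physicochemical assay for lipophilicity, using the shake flask method, in phosphate buffer, measured as octanol-water partition, with a stated time of 30 min, at pH 7.4; a lower number here means a more polar compound, a higher number a more lipophilic compound. Compound 1 `O=C1c2ccccc2CN1c1cnc(NCc2c(F)ccc3c2CCO3)n2cnnc12` gives 2.7. Compound 2 `Cc1ncccc1-c1cnc(NCc2c(F)ccc3c2CCO3)c2n[nH]c(=O)n12` gives 2.5, and compound 3 `CN(C)Cc1ccc2c(c1)CN(c1cnc(NCc3c(F)ccc4c3CCO4)c3cn[nH]c(=O)c13)C2=O` gives 2.2. Compound 1 stands highest of the three, though its nearest neighbour compound 2 is only a number within the scatter lower, so no order between those two can be read; compound 3, the furthest, is lower by a margin beyond the scatter. Among the compounds with values here, no two of the measured compounds differ in a single place, so no step within the measured set is available to lean on.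

Compound 4 `CN(c1cccnc1)c1cnc(NCc2c(F)ccc3c2CCO3)n2cnnc12` is not yet measured. It differs from compound 1 by a group of 8 heavy atoms (6 carbon, 2 nitrogen; one six-membered aromatic ring with 1 hetero atom) in place of a group of 10 heavy atoms (8 carbon, 1 nitrogen, 1 oxygen; one five-membered non-aromatic ring with 1 hetero atom, one six-membered aromatic ring of carbon only), on an aromatic carbon. The step from compound 1 to compound 4 in this assay is expected to run downward, somewhat beyond the scatter rather than flat, on the change counted above; the expected step is a number 0.50 log units lower from compound 1 to compound 4 (beyond the scatter). For compound 4 the estimate in this assay is 2.2, with a range from 1.7 to 2.7.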

Compound 4, distribution coefficient: 2.6
For compound 4 the middle estimate is 0.40 log units below the measured one; the range from low to high includes it.
By their numbers in this assay, from the lowest: compounds 3, 2, 4 and 1 (each within the scatter of the next, the first and the last beyond it).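

In this assay the step of a number 0.10 log units lower from compound 1 to compound 4 (within the scatter) gives the series its first comparison in a single place, and it shows that methyl(pyridin-3-yl)amino can stand in place of the group of 10 heavy atoms on this aromatic carbon with no change that can be read. The group that leaves and the group that enters differ in heavy atoms, in rings and in hydrogen-bond acceptors, yet this one pair cannot separate what each of these differences contributes to the read-out. No separate measurement bears on why the number holds across this exchange.

Going by these compounds, whether a carboxylic acid or a morpholine on this same aromatic carbon would also leave the number in place stays open. Equally open, on these data alone, is whether this exchange on the core of compound 2 or compound 3 would give a step of similar size.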